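Heteroaryl variants on the shared core: five- versus six-membered rings

The source may hold more compounds than are shown below. What is called first, only, known or untested is meant among the compounds shown, and "the series" means these compounds.

Compound 1 `CCN(c1ccc(C#N)c(Cl)c1)c1cc(-c2ccoc2)ccc1C`; in a functional assay on CWR22R cells (Homo sapiens) for antiproliferative activity, read by CCK-8 assay, with a stated time of 6 days (on this read-out higher numbers stand for weaker inhibition and lower numbers for stronger inhibition), compound 1 gives > 30000 nM, a limit of the assay.
Compound 2 `CCN(c1ccc(C#N)c(Cl)c1)c1cc(-c2cncnc2)ccc1C`; in this assay compound 2 gives > 30000 nM, likewise a limit.
Compound 3 `CCN(c1ccc(C#N)c(Cl)c1)c1cc(-n2ccnc2)ccc1C`; in this assay compound 3 gives > 30000 nM, again a limit.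

Compound 3 thus stands at the limit where every value in the series sits (the limit of > 30000 nM in this assay, at which 3 of the 3 values shown sit). Compound 4 `CCN(c1ccc(C#N)c(Cl)c1)c1cc(-c2ccncc2)ccc1C` differs from compound 3 in one place: pyridin-4-yl in place of 1H-imidazol-1-yl on an aromatic carbon. The measured steps bear on this change only loosely: a step that the two limits leave unreadable from compound 1 to compound 2, a step that the two limits leave unreadable from compound 1 to compound 3 and a step that the two limits leave unreadable from compound 2 to compound 3. Within the data shown here, since no step yields a readable size or direction, the expectation for compound 4 is a step of about a number no higher from compound 3 to compound 4 (the limit leaves the size open) in this assay, with no direction readable. Compound 4 is estimated at 30000 nM, within 10000 nM to 100000 nM, most likely reported again only as a limit.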

Compound 4, half-maximal inhibitory concentration: 1030 nM
Estimate against measurement, compound 4: 29-fold (1.46 log units) above; measured number below the stated range.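

Among these compounds, at this aromatic carbon, pyridin-4-yl is the first group to give a readable number in this assay, with an at least 29-fold lower number from compound 3 to compound 4 (1.46 log units; beyond the scatter), an at least 29-fold lower number from compound 2 to compound 4 (1.46 log units; beyond the scatter) and an at least 29-fold lower number from compound 1 to compound 4 (1.46 log units; beyond the scatter). Compound 2 also carries a six-membered aromatic ring and gives > 30000 nM, a limit, so a six-membered aromatic ring alone does not suffice. The steps among compound 1, compound 2 and compound 3 cannot be read, and most of the series stays at the limit: the limit of > 30000 nM in this assay, at which 3 of the 4 values shown sit.

As far as these compounds go, the full size of the steps to compound 4 stays open. Also open, from the compounds shown here alone, is how a plain phenyl ring or an amine would behave at this carbon.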